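A few compounds are considered here, and "the series" means these few. Any claim that something is new, unique, unknown or untested is made for them only; others in the source may bear on it.

Measured so far, in a functional assay on HepG2 cells (Homo sapiens) for cytotoxicity, read by MTT assay, with a stated time of 72 h; on this read-out higher numbers stand for weaker inhibition of growth and lower numbers for stronger inhibition of growth:
compound 1 `O=C(/N=C(/NC(=O)c1cc(-c2ccccc2)nc2ccccc12)[Se]Cc1ccccc1)c1cc(-c2ccccc2)nc2ccccc12` gives 25800 nM;
compound 2 `CS/C(=N\C(=O)c1cc(-c2ccccc2)nc2ccccc12)NC(=O)c1cc(-c2ccccc2)nc2ccccc12` gives 6240 nM.

Compound 2 stands at the lower of the two numbers; its nearest neighbour is compound 1, and the step of a 4.1-fold lower number from compound 1 to compound 2 (0.62 log units; beyond the scatter) lies beyond the scatter. Compound 3 `C[Se]/C(=N\C(=O)c1cc(-c2ccccc2)nc2ccccc12)NC(=O)c1cc(-c2ccccc2)nc2ccccc12` differs from compound 2 by a group of 2 heavy atoms (1 carbon, 1 selenium; no ring) in place of a group of 2 heavy atoms (1 carbon, 1 sulfur; no ring), on a carbon with a double bond to nitrogen. Within the data shown here, the one measured step, a 4.1-fold lower number from compound 1 to compound 2 (0.62 log units; beyond the scatter), exchanged the selenium-bearing group for a sulfur-bearing one but also swapped a benzyl for a methyl, so it bears on the present change only loosely; no measured pair isolates the sulfur-to-selenium exchange by itself. In this assay no step beyond the scatter is therefore expected. Compound 3 is estimated at 7500 nM (range 3000 nM to 18000 nM), which means a 1.2-fold higher number from compound 2 to compound 3 (0.08 log units; within the scatter).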

Compound 3, concentration for 50% growth inhibition: 4540 nM
Compound 3: the middle estimate sits 1.7-fold (0.22 log units) above what was measured; measured number inside the range.
By their numbers in this assay, from the lowest: compounds 3 and 2 (each within the scatter of the next); then compound 1.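

In this assay, replacing methylsulfanyl with its selenium counterpart on a carbon with a double bond to nitrogen gives a 1.4-fold lower number from compound 2 to compound 3 (0.14 log units; within the scatter), so this single-place pair shows no separation between sulfur and selenium here. With selenium held constant, a 5.7-fold lower number from compound 1 to compound 3 (0.75 log units; beyond the scatter) ties a difference beyond the scatter to hydrogen in place of phenyl on the saturated chain carbon bound to selenium. Nothing measured bears on the reason for either step. Open, as far as these compounds go, is how an ethyl or longer chain on selenium would compare with methyl and benzyl. Also open, from the compounds shown here alone, is whether an amine or methoxy on the same carbon would keep these numbers.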